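The source may hold more compounds than are shown below. What is called first, only, known or untested is meant among the compounds shown, and "the series" means these compounds.

Compound 1 `CC(=O)Nc1cccc2c(-c3cccc(NC(=O)c4ccc(C)c(C)c4)c3)ccnc12` in a functional assay on A375P cells (Homo sapiens) for antiproliferative activity, read by MTT assay, with a stated time of 48 h (a higher number here means a weaker inhibitor, a lower number a stronger inhibitor), gives > 20000 nM, which is a limit of the assay and not a number.
Compound 2 `CC(=O)Nc1cccc2c(-c3cccc(NC(=O)c4ccc(Br)c(C)c4)c3)ccnc12` in this assay gives > 20000 nM, likewise a limit.
Compound 3 `CC(=O)Nc1cccc2c(-c3cccc(NC(=O)c4cccc(C(F)(F)F)c4)c3)ccnc12` in this assay gives 8000 nM.

For the measured compounds named here, compound 3 therefore holds the only number in this set; the other two values sit at the limit of > 20000 nM in this assay, at which 2 of the 3 values shown sit. The step that the two limits leave unreadable from compound 1 to compound 2 cannot be sized for that reason. The two steps that end at compound 3 are readable: an at least 2.5-fold lower number from compound 1 to compound 3 (0.39 log units; beyond the scatter) and an at least 2.5-fold lower number from compound 2 to compound 3 (0.39 log units; beyond the scatter). Both exchange the aryl on the carbonyl carbon, and both lower the number by at least a modest amount, so compound 3 carries the aryl that has done best so far.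

Compound 4 `CC(=O)Nc1cccc2c(-c3cccc(NC(=O)c4ccc(C(F)(F)F)c(Cl)c4)c3)ccnc12` is not yet measured. It differs from compound 3 in one place: 3-chloro-4-(trifluoromethyl)phenyl in place of 3-(trifluoromethyl)phenyl on a carbonyl carbon. Going by the values given here, no measured pair isolates either the entry of the chloro or the changed placing of the trifluoromethyl; the measured steps show only that exchanging this aryl can move the number beyond the scatter, in either direction relative to an unknown baseline. For compound 4 in this assay a step of a 1.3-fold lower number from compound 3 to compound 4 (0.12 log units; within the scatter) is expected, within the scatter. The estimate for compound 4 is 6000 nM, with a range from 2000 nM to 20000 nM.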

Compound 4, half-maximal inhibitory concentration: 7600 nM
For compound 4 the middle estimate is 1.3-fold (0.10 log units) below the measured one; low and high end bracket the measured number.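

In this assay, the exchange at this carbonyl carbon reads as a 1.1-fold lower number from compound 3 to compound 4 (0.02 log units; within the scatter), so the 3-chloro-4-(trifluoromethyl)phenyl group and the 3-(trifluoromethyl)phenyl group cannot be told apart here, even though the new group brings in a chloro and places the trifluoromethyl differently. Compound 4 also gives a second readable exchange away from each of the two earlier aryls, with an at least 2.6-fold lower number from compound 2 to compound 4 (0.42 log units; beyond the scatter) and an at least 2.6-fold lower number from compound 1 to compound 4 (0.42 log units; beyond the scatter), so among the four compounds, both aryls bearing trifluoromethyl stand apart from the 4-bromo-3-methylphenyl and 3,4-dimethylphenyl groups. Those two steps start from a limit of the assay and not a number, so their true size stays unknown: the limit of > 20000 nM in this assay, at which 2 of the 4 values shown sit.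

The compounds shown do not separate the contribution of the chloro from that of the changed trifluoromethyl placing, and the two effects may offset each other or both be small. Going by these compounds, how a phenyl bearing a nitrile, a methoxy group or an amine on this carbonyl carbon would read in this assay also remains open.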